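The source may hold more compounds than are shown below. What is called first, only, known or untested is meant among the compounds shown, and "the series" means these compounds.

Measured compounds:
compound 1 `COc1ccc(-c2cn3cc(C4=CCN(C(=O)c5ccc(Cl)cc5)CC4)ccc3n2)cc1OC` gives 8970 nM in a functional assay on A549 cells (Homo sapiens) for antiproliferative activity, read by MTT assay, with a stated time of 48 h; on this read-out higher numbers stand for weaker inhibition and lower numbers for stronger inhibition
compound 2 `COc1ccc(-c2cn3cc(C4=CCN(S(=O)(=O)c5ccccc5)CC4)ccc3n2)cc1OC` gives 7660 nM in this assay
compound 3 `COc1ccc(-c2cn3cc(C4=CCN(C(=O)c5ccccc5)CC4)ccc3n2)cc1OC` gives 7700 nM in this assay

All three compounds share one core and differ only in the group attached to the ring nitrogen. Compound 3, with a benzoyl on that nitrogen, sits close to both neighbours: the steps of a 1.2-fold lower number from compound 1 to compound 3 (0.07 log units; within the scatter) and a 1.0-fold higher number from compound 2 to compound 3 (0.00 log units; within the scatter) are both within the scatter, so none of the three can be set apart from the others.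

Compound 4 `COc1ccc(-c2cn3cc(C4=CCN(C(=O)C5CC5)CC4)ccc3n2)cc1OC` is the next compound, still unmeasured. Relative to compound 3 the change is cyclopropyl in place of phenyl on a carbonyl carbon.

Among the measured compounds shown here, the steps that bear on this are the two that alter the group on the ring nitrogen: a 1.2-fold lower number from compound 1 to compound 2 (0.07 log units; within the scatter) and a 1.0-fold higher number from compound 2 to compound 3 (0.00 log units; within the scatter). Both were within the scatter, which suggests that this position tolerates exchange of one aromatic group for another without a visible effect. For the measured compounds named here, the exchange of phenyl for cyclopropyl is a different kind of change, and no measured pair covers it, so the expectation rests on the tolerance seen so far. A step of a 1.2-fold higher number from compound 3 to compound 4 (0.09 log units; within the scatter) is expected, with no clear direction beyond the scatter. Compound 4 is therefore estimated at 9500 nM in this assay, within a range from 3500 nM to 28000 nM.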

Compound 4, half-maximal inhibitory concentration: 9140 nM
Estimate against measurement, compound 4: 1.0-fold (0.02 log units) above; low and high end bracket the measured number.
By their numbers in this assay, from the lowest: compounds 2, 3, 1 and 4 (each within the scatter of the next).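

Among the compounds shown here, earlier comparisons on this ring nitrogen involved only groups carrying an aromatic ring, so they could not show whether that ring mattered. In this assay, replacing the six-carbon aromatic phenyl with the three-carbon non-aromatic cyclopropyl on the carbonyl carbon gives a 1.2-fold higher number from compound 3 to compound 4 (0.07 log units; within the scatter), so among these compounds the aromatic ring is not needed to keep this level of antiproliferative activity. The same holds for the wider exchanges, with a 1.2-fold higher number from compound 2 to compound 4 (0.08 log units; within the scatter) and a 1.0-fold higher number from compound 1 to compound 4 (0.01 log units; within the scatter), although nothing available explains why the position responds so little.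

Going by these compounds, it remains open whether any group on this nitrogen can move the number beyond the scatter. A carboxylic acid, a basic amine on a longer chain, or a simple hydrogen on the ring nitrogen would test this.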